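Weak Antiproliferative Inhibition and a Fluorinated Analogue

This account rests on a few compounds, and the source may have more. Where it says the series, first, only, none or still open, it means among the compounds named here.

- compound 1 `OC[C@H]1O[C@@H](n2cnc3c(NCc4ccc(Cl)c(Cl)c4)ncnc32)[C@H](O)[C@@H]1O`: 145000 nM
- compound 2 `COc1cccc(CNc2ncnc3c2ncn3[C@@H]2O[C@H](CO)[C@@H](O)[C@H]2O)c1OC`: "not determined" (no result reported)

In a functional assay on G-361 cells (Homo sapiens) for antiproliferative activity, with a stated time of 72 h (a higher number here means a weaker inhibitor, a lower number a stronger inhibitor), compound 1 gives 145000 nM, so a very high concentration is needed to reach half-maximal inhibition. Compound 2 gives no single number, and its entry reads "not determined" (no result reported). It therefore has no place on the potency scale.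

Compound 3 `OC[C@H]1O[C@@H](n2cnc3c(NCc4ccc(F)c(F)c4F)ncnc32)[C@H](O)[C@@H]1O` has not yet been measured. The structural change is 2,3,4-trifluorophenyl in place of 2,3-dimethoxyphenyl on a saturated chain carbon bound to a nitrogen on an aromatic ring.

Without a number for compound 2, the size and direction of this step in this assay cannot be read from the data. Among the measured compounds shown here, the only available anchor is compound 1 at 145000 nM, which shares its core with compound 3 and also carries halogen atoms on its phenyl ring. On that single comparison, compound 3 is expected to stay a weak inhibitor, with no shift from compound 1 beyond the usual scatter.

For compound 3, the estimated value is 80000 nM, with an expected range from 15000 nM to 250000 nM.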

Compound 3, half-maximal inhibitory concentration: > 166000 nM
Compound 3: no number, only a limit (the forecaster's own chance of this, stated with the estimate: 30%); at least 2.0-fold (0.31 log units) between middle value and limit.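

Compound 3 carries a limit of the assay, not a number: the limit of > 166000 nM in this assay, at which 1 of the 3 values shown sits.

Placing 2,3,4-trifluorophenyl where compound 1 has 3,4-dichlorophenyl, on the same saturated chain carbon bound to a nitrogen on an aromatic ring, gives an at least 1.1-fold higher number from compound 1 to compound 3 (0.05 log units; that floor lies within the scatter), so neither compound can be ranked over the other. What this adds is a second halogen-bearing phenyl group at this position, and exchanging chlorine atoms for fluorine atoms, with one more halogen on the ring, yields no stronger inhibitor in this assay.

The step between compound 2 and compound 3 cannot be read, since compound 2 has no result, and so the data say nothing about how 2,3-dimethoxyphenyl compares with either halogenated phenyl group here. Also open, as far as these compounds go, is whether a phenyl ring bearing an amine or a carboxylic acid, or a longer chain joining the ring to the nitrogen, would bring the number down from this very weak range on the shared core.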